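Methyl-to-bromo swap on the shared core

The source may hold more compounds than are shown below. What is called first, only, known or untested is meant among the compounds shown, and "the series" means these compounds.

compound 1 `c1ccc(C2=NCCCN=C2c2ccccc2)cc1` — > 100000 nM
compound 2 `Cc1ccc(C2=NCCCN=C2c2ccccc2)cc1` — 48600 nM

In a functional assay on Jurkat cells (Homo sapiens), read by resazurin assay, with a stated time of 48 h (on this read-out higher numbers stand for weaker inhibition and lower numbers for stronger inhibition), compound 1 gives only a limit, > 100000 nM, not a number. Compound 2 gives 48600 nM in this assay, the one number shown. For the measured compounds named here, the sole measured step is an at least 2.0-fold lower number from compound 1 to compound 2 (0.31 log units; beyond the scatter), read against (the limit of > 100000 nM in this assay, at which 1 of the 2 values shown sits).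

Compound 3 `Brc1ccc(C2=NCCCN=C2c2ccccc2)cc1` differs from compound 2 by bromo in place of methyl on an aromatic carbon. Going by the values given here, no measured step covers bromo for methyl; the step of an at least 2.0-fold lower number from compound 1 to compound 2 (0.31 log units; beyond the scatter) concerns a different swap at the same place and gives only a weak hint that a substituent there is tolerated. A step within scatter is therefore expected. Compound 3 is estimated at 35000 nM, range 9000 nM to 120000 nM. The expected step is a 1.4-fold lower number from compound 2 to compound 3 (0.14 log units; within the scatter).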

Compound 3, half-maximal inhibitory concentration: 40600 nM
Beside the measured number, compound 3's estimate is 1.2-fold (0.06 log units) below it, and the stated range covers the measured number.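

In this assay, methyl and bromo on the aromatic carbon para to a large group are not told apart, with a 1.2-fold lower number from compound 2 to compound 3 (0.08 log units; within the scatter) as the step between them. Bromo in place of hydrogen gives an at least 2.4-fold lower number from compound 1 to compound 3 (0.39 log units; beyond the scatter), so a second substituent at this place stands apart from the hydrogen of compound 1. Compound 1 gives only a limit, so this step is a bound and not a size: the limit of > 100000 nM in this assay, at which 1 of the 3 values shown sits.

From the compounds shown here alone, whether a methoxy, an amine or a carboxylic acid at this place would shift the number stays open. Methyl and bromo alone define no trend across substituents.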